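Two Compounds at the Limit and a Pyrimidin-2-yl Swap

A few compounds are considered here, and "the series" means these few. Any claim that something is new, unique, unknown or untested is made for them only; others in the source may bear on it.

Compound 1, `N#Cc1ccc(Nc2nc(Oc3ccnc4ccccc34)nc(N3CCN(c4ccc(F)cc4)CC3)n2)cc1C(F)(F)F`: in a functional assay on DU-145 cells (Homo sapiens) for cytotoxicity, read by sulforhodamine B assay, with a stated time of 48 h (a lower number here means a stronger inhibitor of growth, a higher number a weaker inhibitor of growth), compound 1 gives > 100000 nM, which is a limit of the assay.
Compound 2, `COc1ccc(N2CCN(c3nc(Nc4ccc(C#N)c(C(F)(F)F)c4)nc(Oc4ccnc5ccccc45)n3)CC2)cc1`: in this assay compound 2 gives > 100000 nM, again a limit of the assay rather than a number.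

Compound 2 therefore stands nowhere on a scale of numbers in this assay; both values shown sit at the limit of > 100000 nM in this assay, at which 2 of the 2 values shown sit. For the measured compounds named here, the one measured change, a step that the two limits leave unreadable from compound 1 to compound 2, cannot be read for size or direction, since a step between two limits tells nothing about how far either compound lies beyond them.

Compound 3, `N#Cc1ccc(Nc2nc(Oc3ccnc4ccccc34)nc(N3CCN(c4ncccn4)CC3)n2)cc1C(F)(F)F`, differs from compound 2 by pyrimidin-2-yl in place of 4-methoxyphenyl on an amine nitrogen in a ring. No measured step touches this kind of replacement: the only step shown concerns a substituent on a different aromatic carbon and is itself unreadable. With the two shared-core compounds both at the limit and no readable step to lean on, compound 3 is expected to remain at or close to the limit in this assay, and the expected step of a number no higher from compound 2 to compound 3 (the limit leaves the size open) is put at none beyond the scatter. The estimate for compound 3 in this assay is 100000 nM, within a range from 30000 nM to 300000 nM.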

Compound 3, concentration for total growth inhibition: > 100000 nM
Compound 3 ended at the assay's limit; the forecaster's own chance of this, stated with the estimate: 70%; the middle value sits exactly at the limit.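

Compound 3 gives > 100000 nM in this assay, which is a limit of the assay and not a number. No new step can be read among compound 1, compound 2 and compound 3, since all three sit at the same limit: the limit of > 100000 nM in this assay, at which 3 of the 3 values shown sit.

The compounds shown leave open how far beyond that limit each lies and whether exchanging the group on the amine nitrogen in a ring changes growth inhibition at all.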